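Benzyl in place of aryl on the ring nitrogen: cytotoxicity

A few compounds are considered here, and "the series" means these few. Any claim that something is new, unique, unknown or untested is made for them only; others in the source may bear on it.

Measured so far:
compound 1 `COc1ccc(Nc2nc(/C=C/c3cc(OC)c(OC)c(OC)c3)nc3ccsc23)cc1` gives > 50000 nM
compound 2 `COc1cc(/C=C/c2nc(NCc3ccc(C)cc3)c3sccc3n2)cc(OC)c1OC` gives > 50000 nM

Both values are limits of an ADME assay on RAW264.7 cells (Mus musculus) for cytotoxicity, read by MTT assay (on this read-out higher numbers stand for weaker inhibition and lower numbers for stronger inhibition), not numbers. In this assay compound 1 sits at the limit > 50000 nM. Compound 2 likewise sits at its limit > 50000 nM. The step that the two limits leave unreadable from compound 1 to compound 2 therefore has no readable size. Compound 1 stands where all values shown stand (the limit of > 50000 nM in this assay, at which 2 of the 2 values shown sit).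

Compound 3 `COc1cc(/C=C/c2nc(NCc3ccc(Cl)cc3)c3sccc3n2)cc(OC)c1OC` differs from compound 1 by 4-chlorobenzyl in place of 4-methoxyphenyl on a nitrogen on an aromatic ring. For the measured compounds named here, the only measured step bearing on this change is a step that the two limits leave unreadable from compound 1 to compound 2, which alters the same nitrogen and yields no readable size. No step beyond the scatter is expected in this assay, and compound 3 is expected to remain at the limit. The step this expectation means is a step that the limit leaves unreadable from compound 1 to compound 3. The estimate for compound 3 is 80000 nM, with a range from 30000 nM to 200000 nM.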

Compound 3, half-maximal inhibitory concentration: > 50000 nM
Compound 3 was reported as a limit (the forecaster's own chance of this, stated with the estimate: 85%); the middle value lies beyond the limit too.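

No new step can be read among compound 1, compound 2 and compound 3, since all three stand as limits and not as numbers in this assay: the limit of > 50000 nM in this assay, at which 3 of the 3 values shown sit.

The compounds shown leave open how far each lies past that limit, and whether any group on this nitrogen gives a measurable value in this assay.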